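This account rests on a few compounds, and the source may have more. Where it says the series, first, only, none or still open, it means among the compounds named here.

Working notes on the series.

Compound 1, `COc1ccc(/C=C/c2cc(=O)cco2)cc1`, is the reference point. In an ADME assay on HaCaT cells (Homo sapiens) for inhibition, read by sulforhodamine B assay, with a stated time of 48 h (on this read-out lower numbers stand for stronger inhibition of growth and higher numbers for weaker inhibition of growth), compound 1 gives 710 uM. Compound 2, `COc1ccc(/C=C/c2cc(=O)cco2)cc1OC`, carries one change relative to compound 1, (methoxy in place of hydrogen on an aromatic carbon), and in this assay compound 2 gives 690 uM; the step of a 1.0-fold lower number from compound 1 to compound 2 (0.01 log units; within the scatter) lies within the scatter, so the two values are read as the same. Compound 3, `COc1ccc(/C=C/C2CC=CC(=O)O2)cc1OC`, has a different core; how the two cores differ is not broken down here. In this assay compound 3 gives 63 uM, the lowest of the three numbers, and its distance from compound 2 and from compound 1 is beyond the scatter.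

Compound 4, `COc1cc(OC)c(OC)cc1/C=C/C1CC=CC(=O)O1`, is not yet measured. Relative to compound 3 the change is methoxy in place of hydrogen on an aromatic carbon. This is the same kind of change as that from compound 1 to compound 2, but the surroundings differ: from compound 1 to compound 2 the entering methoxy sits ortho to a methoxy group and meta to a group of 9 heavy atoms, whereas from compound 3 to compound 4 it sits ortho to a group of 9 heavy atoms, meta to a methoxy group and para to a methoxy group. Apart from the pair of compound 1 and compound 2, no other measured pair among the compounds shown carries this change, so that pair is the only guide.

For compound 4 in this assay the expected step is a 1.1-fold lower number from compound 3 to compound 4 (0.02 log units; within the scatter), because a 1.0-fold lower number from compound 1 to compound 2 (0.01 log units; within the scatter) stayed within the scatter. The estimate for compound 4 is therefore 60 uM, with a range from 25 uM to 150 uM. This rests on compound 3, which gives 63 uM.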

Compound 4, concentration for growth inhibition (reported as GI): 46.9 uM
The estimate for compound 4 lay 1.3-fold (0.11 log units) above the measured number; the measured number falls inside the stated range.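

In this assay methoxy in place of hydrogen on an aromatic carbon gives a 1.3-fold lower number from compound 3 to compound 4 (0.13 log units; within the scatter), so compound 3 and compound 4 are read as the same. The change thus stays within the scatter on both cores, and the two steps do not differ: the same change on two cores in this assay, a 1.0-fold lower number (0.01 log units; within the scatter) from compound 1 to compound 2 and a 1.3-fold lower number (0.13 log units; within the scatter) from compound 3 to compound 4, 1.3-fold (0.12 log units) apart, within the scatter of two such steps

This supports carrying the change between these two cores only for these two pairs and this read-out; it does not show that methoxy makes no difference at every place on the ring or on any other core, and core and place vary together here, with the entering methoxy ortho to a group of 9 heavy atoms, meta to a methoxy group and para to a methoxy group only in compound 4.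

The compounds shown leave open whether a hydroxyl group, a chlorine atom, an amine or a carboxylic acid in place of that hydrogen would also stay within the scatter on both cores. Going by these compounds, it is also open whether a longer chain, such as ethoxy or butoxy, would behave as methoxy does.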